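Amidoxime series: aryl variation and expectation for compound 4

This account rests on a few compounds, and the source may have more. Where it says the series, first, only, none or still open, it means among the compounds named here.

Measured so far in an assay on isolated protein for inhibition of Indoleamine 2,3-dioxygenase 1 (Homo sapiens), read by spectrophotometry, with a stated time of 1 h; a lower number here means a stronger inhibitor, a higher number a weaker inhibitor:
compound 1 `O=[N+]([O-])c1ccc(N/C(=N\O)c2ccccc2Cl)c2nonc12`, 135 nM
compound 2 `Cc1cccc(/C(=N/O)Nc2ccc([N+](=O)[O-])c3nonc23)c1`, 163 nM
compound 3 `O=[N+]([O-])c1ccc(N/C(=N\O)c2cccc(F)c2)c2nonc12`, 75 nM

Compound 3 holds the lowest of the three numbers. The two steps that end at it are a 1.8-fold lower number from compound 1 to compound 3 (0.26 log units; within the scatter) and a 2.2-fold lower number from compound 2 to compound 3 (0.34 log units; beyond the scatter); compound 1 and compound 2 differ by a 1.2-fold higher number from compound 1 to compound 2 (0.08 log units; within the scatter).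

Compound 4 `O=[N+]([O-])c1ccc(N/C(=N\O)c2ccc(F)c(Br)c2)c2nonc12` is unmeasured. Change from compound 3: 3-bromo-4-fluorophenyl in place of 3-fluorophenyl on a carbon with a double bond to nitrogen

All three measured steps alter only the aryl group on the same carbon, and each stayed small, so a further aryl change is expected to move this assay little. No step beyond the scatter is expected for compound 4, its estimated step being a 1.1-fold higher number from compound 3 to compound 4 (0.05 log units; within the scatter). Compound 4 is estimated at 85 nM, range 35 nM to 200 nM.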

Compound 4, half-maximal inhibitory concentration: 92 nM
For compound 4 the middle estimate is 1.1-fold (0.03 log units) below the measured one, and the stated range covers the measured number.
By their numbers in this assay, from the lowest: compounds 3, 4, 1 and 2 (each within the scatter of the next, the first and the last beyond it).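

In this assay, the 3-bromo-4-fluorophenyl group, the only aryl group shown that carries bromine or two substituents, stays within the scatter of all three earlier aryl groups: a 1.2-fold higher number from compound 3 to compound 4 (0.09 log units; within the scatter), a 1.5-fold lower number from compound 1 to compound 4 (0.17 log units; within the scatter) and a 1.8-fold lower number from compound 2 to compound 4 (0.25 log units; within the scatter). On this carbon with a double bond to nitrogen, adding bromine to a fluorinated ring therefore leaves the number in the same range. Nothing available explains these small steps.

From the compounds shown here alone, whether an amine or a carboxylic acid on the aryl ring would keep the number in this range remains open. So does the effect of any change to the shared core.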